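The source may hold more compounds than are shown below. What is called first, only, known or untested is meant among the compounds shown, and "the series" means these compounds.

- compound 1 `CCNC(=O)c1noc(-c2cc(C(C)C)c(O)cc2O)c1-c1cc(CO)no1`: 13 nM
- compound 2 `CCNC(=O)c1noc(-c2cc(C(C)C)c(O)cc2O)c1-c1ccn(C)n1`: 16 nM

Both compounds were tested in a functional assay on HCT-116 cells (Homo sapiens) for inhibition; a higher number here means a weaker inhibitor, a lower number a stronger inhibitor. There, compound 2 gives 16 nM, the higher of the two numbers, but the gap to compound 1 lies within the scatter, so the pair cannot be ranked. Compound 3 `CCNC(=O)c1noc(-c2cc(C(C)C)c(O)cc2O)c1-c1cnn(C)c1` has not been measured yet. It has the same atoms as compound 2, joined differently: 1-methyl-1H-pyrazol-4-yl in place of 1-methyl-1H-pyrazol-3-yl on an aromatic carbon. Within the data shown here, only one measured step bears on this change, a 1.2-fold higher number from compound 1 to compound 2 (0.09 log units; within the scatter). That step exchanged one five-membered aromatic ring for another on the same aromatic carbon and stayed within the scatter. Among the measured compounds shown here, no measured pair tests the new attachment point directly, so the expectation is uncertain. The expected 1.1-fold lower number from compound 2 to compound 3 (0.03 log units; within the scatter), which means no step beyond the scatter in either direction. Compound 3 is estimated at 15 nM, with an expected range of 6 nM to 40 nM.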

Compound 3, half-maximal inhibitory concentration: 41 nM
For compound 3 the middle estimate is 2.7-fold (0.44 log units) below the measured one; the measured number lies above the stated range.
By their numbers in this assay, from the lowest: compounds 1 and 2 (each within the scatter of the next); then compound 3.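

Swapping 1-methyl-1H-pyrazol-3-yl for 1-methyl-1H-pyrazol-4-yl keeps the same atoms and the same counted features, yet in this assay it gives a 2.6-fold higher number from compound 2 to compound 3 (0.41 log units; beyond the scatter). This position therefore responds to how the ring is joined to the core, and not only to which ring is present, a difference the earlier exchange of rings did not reveal. The 1-methyl-1H-pyrazol-4-yl group also separates from the 3-(hydroxymethyl)-1,2-oxazol-5-yl group, with a 3.2-fold higher number from compound 1 to compound 3 (0.50 log units; beyond the scatter), and nothing measured here accounts for either modest step.

On these data alone, it remains open whether the way of joining matters equally for other rings at this position, such as a pyridine or a thiazole. Also open, as far as these compounds go, is what an amine or a longer chain in place of the pyrazole methyl would do to the number.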